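The source may hold more compounds than are shown below. What is called first, only, known or untested is meant among the compounds shown, and "the series" means these compounds.

Compound 1, `COc1ccc2c(c1)OC(c1cc(OC)c(OC)c(OC)c1)C(C(C)=O)=C2`, is the anchor of this small set. In a functional assay for inhibition of nuclear factor NF-kappa-B complex (Homo sapiens) (on this read-out lower numbers stand for stronger inhibition and higher numbers for weaker inhibition), compound 1 gives 14100 nM, the lowest of the two numbers recorded, while compound 2, `CCOC(=O)C1=Cc2ccc(OC)cc2OC1c1cc(OC)c(OC)c(OC)c1`, sits close to it at 25000 nM. Compound 3, `COc1ccc2c(c1)OC(c1cc(OC)c(OC)c(OC)c1)C(C(N)=O)=C2`, reaches only a limit of this assay at > 50000 nM. The change from compound 1 to compound 4, `COc1ccc2c(c1)OC(c1cc(OC)c(OC)c(OC)c1)C(C(=O)N(C)C)=C2`, is dimethylamino in place of methyl on a carbonyl carbon. Among the compounds with values here, two measured steps bear on it. Ethoxy in place of methyl on a carbonyl carbon gave a 1.8-fold higher number from compound 1 to compound 2 (0.25 log units; within the scatter), whereas amino in place of methyl on a carbonyl carbon gave an at least 3.5-fold higher number from compound 1 to compound 3 (0.54 log units; beyond the scatter), bounded by the limit of > 50000 nM in this assay, at which 1 of the 3 values shown sits. Since dimethylamino in place of methyl, read as acetyl to dimethylcarbamoyl, resembles the amino step more than the ethoxy step, a weakening of at least modest size is expected in this assay, and the step is estimated at a 2.3-fold higher number from compound 1 to compound 4 (0.36 log units; beyond the scatter). Compound 4 is therefore expected to show 32000 nM in this assay, within a range from 12000 nM to 80000 nM, with a real chance that only a limit is reported.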

Compound 4, half-maximal inhibitory concentration: > 50000 nM
Compound 4 ended at the assay's limit; the forecaster's own chance of this, stated with the estimate: 35%; middle value at least 1.5-fold (0.19 log units) away from the limit.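

In this assay, dimethylamino in place of methyl on a carbonyl carbon gives an at least 3.5-fold higher number from compound 1 to compound 4 (0.54 log units; beyond the scatter), so a second nitrogen-bearing group, after amino, also stands beyond the scatter from the acetyl of compound 1. Against the ethoxy group the reading is less firm: swapping that group for dimethylamino gives an at least 2.0-fold higher number from compound 2 to compound 4 (0.30 log units; that floor lies within the scatter). The step between compound 3 and compound 4 cannot be read, since both values are limits: the limit of > 50000 nM in this assay, at which 2 of the 4 values shown sit.

On these data alone, how far compound 3 and compound 4 actually lie past that limit remains open, so the amino and dimethylamino groups cannot be ranked. Also open, as far as these compounds go, is whether a carboxylic acid or a longer ketone chain such as propanoyl at this place would keep the number of compound 1 or move it lower.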